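Swapping (methylsulfonyl)methyl for hex-1-en-1-yl on the shared core

A few compounds are considered here, and "the series" means these few. Any claim that something is new, unique, unknown or untested is made for them only; others in the source may bear on it.

Compound 1 `[N-]=[N+]=NCc1cn([C@H]2C[C@H](O)[C@@H](CO)O2)c(=O)[nH]c1=O`: 124000 nM
Compound 2 `O=c1[nH]c(=O)n([C@H]2C[C@H](O)[C@@H](CO)O2)cc1C#CCO`: > 200000 nM
Compound 3 `CS(=O)(=O)Cc1cn([C@H]2C[C@H](O)[C@@H](CO)O2)c(=O)[nH]c1=O`: > 200000 nM

In an ADME assay on L1210/0 cells (Mus musculus) for cytotoxicity, with a stated time of 48 h (a lower number here means a stronger inhibitor, a higher number a weaker inhibitor), compound 3 gives > 200000 nM, which is a limit and not a number. It stands at the limit of > 200000 nM in this assay, at which 2 of the 3 values shown sit. Compound 4 `CCCC/C=C\c1cn([C@H]2C[C@H](O)[C@@H](CO)O2)c(=O)[nH]c1=O` differs from it as follows: hex-1-en-1-yl in place of (methylsulfonyl)methyl on an aromatic carbon. For the measured compounds named here, three measured steps bear on this only loosely, as none brings in hex-1-en-1-yl. They run an at least 1.6-fold higher number from compound 1 to compound 2 (0.20 log units; that floor lies within the scatter), an at least 1.6-fold higher number from compound 1 to compound 3 (0.20 log units; that floor lies within the scatter) and a step that the two limits leave unreadable from compound 2 to compound 3. Only a small drop in this assay is therefore expected, resting on compound 1 at 124000 nM. The expected step runs an at least 1.5-fold lower number from compound 3 to compound 4 (0.18 log units; that floor lies within the scatter). For compound 4 the estimated value is 130000 nM, with an expected range from 40000 nM to 300000 nM.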

Compound 4, half-maximal inhibitory concentration: > 200000 nM
Compound 4 was reported as a limit; the forecaster's own chance of this, stated with the estimate: 40%; at least 1.5-fold (0.18 log units) between middle value and limit.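

Compound 4 also gives only a limit, not a number, so swapping (methylsulfonyl)methyl for hex-1-en-1-yl, which has no hydrogen-bond acceptors, leaves the reading at the same ceiling in this assay: the limit of > 200000 nM in this assay, at which 3 of the 4 values shown sit. For the compounds shown here, the one readable step is an at least 1.6-fold higher number from compound 1 to compound 4 (0.20 log units; that floor lies within the scatter). The other two steps to compound 4 cannot be read, as both ends are limits.

What these compounds leave open is how far above the limit each one lies. Also open, from the compounds shown here alone, is whether an amine or a carboxylic acid at this position would give a measurable value.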